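A few compounds are considered here, and "the series" means these few. Any claim that something is new, unique, unknown or untested is made for them only; others in the source may bear on it.

Measured in an assay on isolated protein for inhibition of Amine oxidase [flavin-containing] A (Homo sapiens), read by fluorescence and spectrophotometry; a higher number here means a weaker inhibitor, a lower number a stronger inhibitor:

- compound 1, `CC(N)CSc1ccccc1Br`, 724 nM
- compound 2, `Cc1cccc(C)c1[Se]CC(C)N`, 1680 nM
- compound 3, `CC(N)C[Se]c1ccc(F)cc1`, 10500 nM

Compound 3 stands at the highest number of the three, so it is the weakest inhibitor of this set. Its nearest neighbour is compound 2, and the gap to compound 2 is already beyond the scatter; the gap to compound 1 is wider still. Compound 1 and compound 2 are separated from each other by a gap that is also beyond the scatter.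

The next compound, compound 4, `Cc1ccc([Se]CC(C)N)cc1`, is not yet measured. Against compound 3 the change is methyl in place of fluoro on an aromatic carbon. For the measured compounds named here, no measured pair in this set isolates that single exchange, so the size of the step is open. Given that compound 3 sits at the weak end of the series with 10500 nM, a moderate step toward a lower number in this assay is expected for compound 4, though a step within the scatter cannot be excluded. The expected step is a 2.1-fold lower number from compound 3 to compound 4 (0.32 log units; beyond the scatter). Compound 4 is therefore estimated at 5000 nM, with a range from 1500 nM to 15000 nM.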

Compound 4, half-maximal inhibitory concentration: 2030 nM
Beside the measured number, compound 4's estimate is 2.5-fold (0.39 log units) above it; low and high end bracket the measured number.
By their numbers in this assay, from the lowest: compound 1; then compounds 2 and 4 (each within the scatter of the next); then compound 3.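

In this assay, for the compounds shown here, methyl in place of fluoro on an aromatic carbon, para to a group of 5 heavy atoms, gives a 5.2-fold lower number from compound 3 to compound 4 (0.71 log units; beyond the scatter) and provides the first single-place comparison. The position therefore responds to the identity of its substituent, even though the exchange leaves the heavy-atom count unchanged and neither group carries a ring, a hydrogen-bond donor or acceptor, or a net charge. Nothing measured alongside these values accounts for the step, so only its size and direction can be recorded.

From the compounds shown here alone, one pair defines this position, so it remains open whether the response follows any trend across substituents such as chloro, methoxy or trifluoromethyl, or whether hydrogen at this position would fall on either side of the fluoro and methyl compounds. Also open, going by these compounds, are whether the same exchange gives a step of similar size on the core of compound 1, and how a change elsewhere, such as an N-methyl amine in place of the primary amine, would interact with it.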